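A few compounds are considered here, and "the series" means these few. Any claim that something is new, unique, unknown or untested is made for them only; others in the source may bear on it.

Two compounds from this series have numbers in hand. Compound 1 `O=C(Nc1nc2ccc(F)cc2s1)c1cn(-c2ccccc2)nc1-c1ccc(F)cc1` gives 6650 nM in a functional assay on A549 cells (Homo sapiens) for cytotoxicity, read by MTT assay, with a stated time of 72 h; on this read-out higher numbers stand for weaker inhibition and lower numbers for stronger inhibition. Compound 2 `O=C(Nc1nc2ccccc2s1)c1cn(-c2ccccc2)nc1-c1ccc(Cl)cc1` gives 10300 nM in this assay, and it stands at the higher of the two numbers, though the gap to compound 1 lies within the scatter, so the two cannot be set in order on this evidence. Compound 3 `O=C(Nc1nc2ccc(F)cc2s1)c1cn(-c2ccccc2)nc1-c1ccc(Cl)cc1` is not yet measured. It differs from compound 2 in one place: fluoro in place of hydrogen on an aromatic carbon. Among the compounds with values here, no pair of measured compounds shows this change on its own, so nothing in the data fixes its size. Compound 1 carries the same fluoro on the fused ring and gives 6650 nM, which lies within the scatter of compound 2. The step from compound 2 to compound 3 is therefore expected to be small, a 1.3-fold lower number from compound 2 to compound 3 (0.11 log units; within the scatter), with no clear direction beyond the scatter. Compound 3 is accordingly estimated at 8000 nM, in a range from 3000 nM to 20000 nM.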

Compound 3, half-maximal inhibitory concentration: 8860 nM
Estimate against measurement, compound 3: 1.1-fold (0.04 log units) below; low and high end bracket the measured number.
By their numbers in this assay, from the lowest: compounds 1, 3 and 2 (each within the scatter of the next).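

In this assay, fluoro in place of hydrogen on an aromatic carbon of the fused system now has a direct reading, a 1.2-fold lower number from compound 2 to compound 3 (0.07 log units; within the scatter), and this step lies within the scatter. Within the data shown here, compound 3 also gives the first reading of chloro in place of fluoro on an aromatic carbon, a 1.3-fold higher number from compound 1 to compound 3 (0.12 log units; within the scatter), again within the scatter, so neither single change separates the compounds it joins in this assay. No measurement at hand speaks to what lies behind these two steps. The compounds shown leave open whether a group other than a halogen at this place on the fused system, such as methoxy, an amine or a carboxylic acid, would give a step beyond the scatter. Also open, going by these compounds, is whether chloro in place of fluoro reads the same on a compound carrying the 1,3-benzothiazol-2-yl group without fluoro.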